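Removing a Fluoro Group: One Step Measured, One Expected

This account rests on a few compounds, and the source may have more. Where it says the series, first, only, none or still open, it means among the compounds named here.

Measured compounds:
- compound 1, `Cc1cccc(N2CCN(CCCNc3nc(NCc4ccco4)c4ccccc4n3)CC2)c1C`, gives 840 nM in a functional assay on HT-29 cells (Homo sapiens) for cytotoxicity, read by MTT assay, with a stated time of 2 days; on this read-out higher numbers stand for weaker inhibition and lower numbers for stronger inhibition
- compound 2, `Cc1cccc(N2CCN(CCCNc3nc(NCc4ccco4)c4cc(F)ccc4n3)CC2)c1C`, gives 1050 nM in this assay
- compound 3, `CCN(CC)CCNc1nc(NCc2ccco2)c2cc(F)ccc2n1`, gives "not determined" (no result reported) in this assay, that is, no result is reported for it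

Compound 2 and compound 1 differ by hydrogen in place of fluoro on an aromatic carbon, and that step gave a 1.3-fold lower number from compound 2 to compound 1 (0.10 log units; within the scatter). Compound 4, `CCN(CC)CCNc1nc(NCc2ccco2)c2ccccc2n1`, differs from compound 3 by hydrogen in place of fluoro on an aromatic carbon, the same change at the same place. The difference between the core of compound 3 and the core of compound 2 is not broken down here. For compound 3 no number exists, so the step from compound 3 to compound 4 cannot be set beside the measured one. The expectation for compound 4 therefore rests on the measured step from compound 2 to compound 1 lying within the scatter, while its level is an estimate drawn only from the range of compound 1 and compound 2 with a wider margin for the changed core. Compound 4 is expected to give about 3000 nM in this assay, estimated to fall between 800 nM and 12000 nM.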

Compound 4, half-maximal inhibitory concentration: 10300 nM
Compound 4: middle estimate off by 3.4-fold (0.54 log units), on the low side, within the range that was stated.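

Among the compounds shown here, compound 3 has no number in this assay so no step from it to compound 4 can be read. As far as these compounds go, whether swapping fluoro for hydrogen shifts the number on this core stays open. No evidence shown accounts for the result for compound 4.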